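Chloro for Fluoro on the Sulfonyl Aryl Group

The source may hold more compounds than are shown below. What is called first, only, known or untested is meant among the compounds shown, and "the series" means these compounds.

Compound 3 `COc1ccc(-c2cc(=O)c3c(OC)cc(OC)cc3n2S(=O)(=O)c2ccc(F)cc2)cc1` carries a (4-fluorophenyl)sulfonyl group on the aromatic nitrogen of the shared core. In an ADME assay on BJ cells (Homo sapiens) for antiproliferative activity, with a stated time of 72 h (a lower number here means that less compound is needed, a higher number that more compound is needed for the effect), compound 3 gives only a limit, > 65500 nM, and no number. Its two neighbours likewise reach only limits. Compound 1 `COc1ccc(-c2cc(=O)c3c(OC)cc(OC)cc3n2Cc2ccccc2)cc1`, with a benzyl group on that nitrogen, gives a limit of > 34400 nM in this assay. Compound 2 `COc1ccc(-c2cc(=O)c3c(OC)cc(OC)cc3n2S(=O)(=O)c2ccc(C#N)cc2)cc1`, with a (4-cyanophenyl)sulfonyl group there, gives a limit of > 17200 nM in this assay. The three steps between them, a step that the two limits leave unreadable from compound 1 to compound 2, a step that the two limits leave unreadable from compound 1 to compound 3 and a step that the two limits leave unreadable from compound 2 to compound 3, are therefore all unreadable in size, and compound 3 stands at the limit of > 65500 nM in this assay, at which 1 of the 3 values shown sits.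

Compound 4 `COc1ccc(-c2cc(=O)c3c(OC)cc(OC)cc3n2S(=O)(=O)c2ccc(Cl)cc2)cc1` differs from compound 3 in one place: chloro in place of fluoro on an aromatic carbon. Within the data shown here, the step that the two limits leave unreadable from compound 2 to compound 3, an exchange of one substituent for another on the aromatic carbon, is the closest precedent, and its size cannot be read from two limits. The measured steps point in no direction. Compound 4 is therefore expected to behave like compound 3, with an estimated step of an at least 1.0-fold lower number from compound 3 to compound 4 (0.03 log units; that floor lies within the scatter) in this assay, meaning no change beyond the scatter. The estimate for compound 4 in this assay is 60000 nM, within a range from 20000 nM to 150000 nM, most likely again reported only as a limit.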

Compound 4, half-maximal effective concentration: > 34400 nM
Compound 4: a limit, no number; the forecaster's own chance of this, stated with the estimate: 80%; the middle value is on the limit's open side.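

Compound 4, like compound 1, compound 2 and compound 3, gives only a limit in this assay, so none of the steps from those three compounds to compound 4 can be read. The compounds shown leave open whether changing the group on the aromatic nitrogen of the shared core, or the substituent on its sulfonyl aryl group, alters the concentration needed for the effect.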